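Thiazolopyrimidine series: a pyridyl replacement at the thiazole carbon

The source may hold more compounds than are shown below. What is called first, only, known or untested is meant among the compounds shown, and "the series" means these compounds.

Compound 1, `Nc1nc(N2CCN(C(=O)OCc3ccccc3)CC2)c2nc(-c3ccc(F)cc3)sc2n1`: 4900 nM
Compound 2, `Nc1nc(N2CCN(C(=O)COc3ccc(Cl)cc3)CC2)c2nc(CCOc3ccc(F)cc3)sc2n1`: 3540 nM

In a functional assay on cells (Lymphocyte, Homo sapiens) (on this read-out higher numbers stand for weaker inhibition and lower numbers for stronger inhibition), compound 2 gives 3540 nM and compound 1 gives 4900 nM; the two numbers lie within the scatter of each other, so neither compound can be set apart from the other on this assay. Compound 3, `Nc1nc(N2CCN(C(=O)COc3ccc(Cl)cc3)CC2)c2nc(-c3ccncc3)sc2n1`, has not yet been measured. It differs from compound 2 in one place: pyridin-4-yl in place of 2-(4-fluorophenoxy)ethyl on an aromatic carbon. From the compounds shown here alone, the two compounds measured so far differ from each other in two places at once, so no single change has a step of its own, and the size of the step for this replacement is unknown. The two values show that both substituents at this aromatic carbon sit at a similar level. Compound 3 is therefore expected to stay near compound 2, with a step of a 1.3-fold higher number from compound 2 to compound 3 (0.10 log units; within the scatter) that is not expected to go beyond the scatter. The estimate for compound 3 is 4500 nM, with a range from 1500 nM to 13000 nM.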

Compound 3, half-maximal inhibitory concentration: 40 nM
For compound 3 the middle estimate is 110-fold (2.05 log units) above the measured one, and the stated range ends above it.
By their numbers in this assay, from the lowest: compound 3; then compounds 2 and 1 (each within the scatter of the next).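

In this assay, pyridin-4-yl in place of 2-(4-fluorophenoxy)ethyl on this aromatic carbon, next to the ring nitrogen and next to the ring sulfur, gives an 89-fold lower number from compound 2 to compound 3 (1.95 log units; beyond the scatter). Within the data shown here, compounds 1 and 2 had suggested no such sensitivity, but they differ in two places at once, so only this single change shows that the group at this carbon can have a large effect on the read-out. Nothing available here bears on why the step is so large.

The step combines the loss of the chain with the entry of a ring nitrogen, and compound 1, which differs from compound 3 in two places, cannot separate the two. Phenyl or pyridin-3-yl at this carbon, with the rest of compound 3 unchanged, would address what remains open.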